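Amide cap variation in the chlorophenylpiperidine series

The source may hold more compounds than are shown below. What is called first, only, known or untested is meant among the compounds shown, and "the series" means these compounds.

Three compounds share the core of compound 1 `CC(C)C(=O)NC(C(=O)N1CCC(c2ccc(Cl)cc2)CC1)C(C)C` and have been measured in an assay on THP-1 cells for displacement of a labelled ligand from C-C chemokine receptor type 1 (Homo sapiens); a higher number here means a weaker inhibitor, a lower number a stronger inhibitor. In this assay compound 1 gives 388 nM. Compound 2 `Cc1ccc(C(=O)N[C@@H](C(=O)N2CCC(c3ccc(Cl)cc3)CC2)C(C)C)cc1` carries an aromatic amide group, and in this assay compound 2 gives 25 nM, the lowest of the three numbers. Compound 3 `CCCC(NC(=O)c1ccccc1C)C(=O)N1CCC(c2ccc(Cl)cc2)CC1` pairs a different aromatic amide group with a different side chain, and in this assay compound 3 gives 152 nM. Compound 2 stands apart from both: its gap to compound 3 and its wider gap to compound 1 each lie beyond the scatter, so compound 2 is the strongest inhibitor of the three.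

Compound 4 `CC(C)[C@@H](NC(=O)CCCc1ccccc1)C(=O)N1CCC(c2ccc(Cl)cc2)CC1` has not been measured. It differs from compound 2 in one place: 3-phenylpropyl in place of 4-methylphenyl on a carbonyl carbon. Going by the values given here, no step between measured compounds matches this change. Among the compounds with values here, the only guide is that compound 1 gives 388 nM while compound 2 gives 25 nM in this assay; the entering group keeps one aromatic ring but sets it on a chain rather than directly on the carbonyl carbon. A weakening step of moderate size is expected, beyond the scatter but smaller than the gap between compound 2 and compound 1. For compound 4 the expected step is a 4.4-fold higher number from compound 2 to compound 4 (0.64 log units; beyond the scatter). Compound 4 is estimated at 110 nM in this assay, with a range from 30 nM to 400 nM.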

Compound 4, half-maximal inhibitory concentration: 95 nM
For compound 4 the middle estimate is 1.2-fold (0.06 log units) above the measured one; the range from low to high includes it.
By their numbers in this assay, from the lowest: compound 2; then compounds 4 and 3 (each within the scatter of the next); then compound 1.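

The step gives the series its first single-place comparison at the group on the carbonyl carbon: in this assay, 3-phenylpropyl in place of 4-methylphenyl gives a 3.8-fold higher number from compound 2 to compound 4 (0.58 log units; beyond the scatter), which is modest but beyond the scatter. The change therefore has a measurable cost, yet an aromatic ring set directly on the carbonyl carbon is not a requirement for activity at this position, as compound 4 still gives 95 nM with its ring carried on a chain. No evidence is available on what underlies this step.

The compounds shown leave open whether the cost follows from the chain itself or from the loss of the methyl group, a question that plain phenyl on the carbonyl carbon or 3-(4-methylphenyl)propyl in the same place would address. Also open, on these data alone, is how the value changes with chain length and ring substitution, for instance with the shorter benzyl or 2-phenylethyl groups, or with an amine or a carboxylic acid on the ring of 3-phenylpropyl.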